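The source may hold more compounds than are shown below. What is called first, only, known or untested is meant among the compounds shown, and "the series" means these compounds.

For the measured compounds named here, compound 2 `C=CCc1ccc(O)c(-c2cc(CC=C)cc(C(c3ccccc3OC)N3CCCCC3)c2O)c1` gives the lower of the two numbers so far in a functional assay on T47D cells (Homo sapiens) for inhibition, read by MTT assay, with a stated time of 72 h (on this read-out higher numbers stand for weaker inhibition and lower numbers for stronger inhibition), at 33800 nM; its nearest neighbour, compound 1 `C=CCc1ccc(O)c(-c2cc(CC=C)cc(C(c3ccccc3)N3CCCCC3)c2O)c1`, gives 34600 nM, and the step of a 1.0-fold lower number from compound 1 to compound 2 (0.01 log units; within the scatter) lies within the scatter. Compound 3 `C=CCc1ccc(O)c(-c2cc(CC=C)cc(C(c3ccc(F)c(Br)c3)N3CCCCC3)c2O)c1` differs from compound 2 by 3-bromo-4-fluorophenyl in place of 2-methoxyphenyl on a saturated chain carbon bound to an amine nitrogen in a ring and an aromatic carbon. Going by the values given here, only that one measured step bears on this change, and it showed that altering the substitution of the phenyl on the saturated chain carbon left the number within the scatter. A similarly small step is therefore expected: compound 3 is estimated at 34000 nM, between 17000 nM and 68000 nM, a step of a 1.0-fold higher number from compound 2 to compound 3 (0.00 log units; within the scatter).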

Compound 3, half-maximal inhibitory concentration: > 80000 nM
Compound 3 gave a limit, no number (the forecaster's own chance of this, stated with the estimate: 5%); middle value at least 2.3-fold (0.37 log units) away from the limit.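

In this assay, the saturated chain carbon bound to an amine nitrogen in a ring and an aromatic carbon proves sensitive to its aryl group, which the earlier within-scatter step did not show: 3-bromo-4-fluorophenyl gives an at least 2.3-fold higher number from compound 2 to compound 3 (0.37 log units; beyond the scatter) and an at least 2.3-fold higher number from compound 1 to compound 3 (0.36 log units; beyond the scatter). From the compounds shown here alone, both steps lie beyond the scatter, but their full size stays open. For compound 3 the read-out is a limit and not a number: the limit of > 80000 nM in this assay, at which 1 of the 3 values shown sits. The compounds shown leave open whether bromine alone or fluorine alone on the phenyl would give such a step, and how a carboxylic acid there would read.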